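This account rests on a few compounds, and the source may have more. Where it says the series, first, only, none or still open, it means among the compounds named here.

Within the data shown here, compound 3 `COc1ccc2c(c1)NC(=O)CN2c1nc(NC2CC2)nc2ccccc12` sits second highest of the three numbers so far in a functional assay on MDA-MB-231 cells (Homo sapiens) for inhibition, read by sulforhodamine B assay, with a stated time of 48 h (a higher number here means a weaker inhibitor of growth, a lower number a stronger inhibitor of growth), where compound 3 gives 10.5 nM. Its nearest neighbour is compound 2 `COc1ccc2c(c1)NC(=O)CN2c1nc(Nc2ccc(C#N)cc2)nc2ccccc12`, which in this assay gives 8.31 nM, the difference being a 1.3-fold higher number from compound 2 to compound 3 (0.10 log units; within the scatter). The furthest is compound 1 `COc1ccc2c(c1)NC(=O)CN2c1nc(OCC2CC2)nc2ccccc12`, which in this assay gives 45.2 nM; the step of a 4.3-fold lower number from compound 1 to compound 3 (0.63 log units; beyond the scatter) and the step of a 5.4-fold lower number from compound 1 to compound 2 (0.74 log units; beyond the scatter) show that both amino substituents on the shared core gave lower numbers than cyclopropylmethoxy.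

Compound 4 `COc1ccc2c(c1)NC(=O)CN2c1nc(COC(C)=O)nc2ccccc12` differs from compound 3 in one place: acetoxymethyl in place of cyclopropylamino on an aromatic carbon. Acetoxymethyl is neither (4-cyanophenyl)amino nor cyclopropylamino, and no measured pair tests this exact exchange. Among the measured compounds shown here, the steps that bear on it are a 4.3-fold lower number from compound 1 to compound 3 (0.63 log units; beyond the scatter) and a 5.4-fold lower number from compound 1 to compound 2 (0.74 log units; beyond the scatter), both modest and beyond the scatter, and both pointing away from the only non-amino substituent measured. On that basis the step of a 5.7-fold higher number from compound 3 to compound 4 (0.76 log units; beyond the scatter) is expected to run toward a higher number, of a size comparable to those two steps but with wide uncertainty, because compound 1 gives 45.2 nM as the single reference for a non-amino group at this position. For compound 4 the expected result in this assay is 60 nM, with a range from 20 nM to 200 nM.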

Compound 4, concentration for 50% growth inhibition: 8.95 nM
Compound 4: the middle estimate sits 6.7-fold (0.83 log units) above what was measured; the measured number lies below the stated range.
By their numbers in this assay, from the lowest: compounds 2, 4 and 3 (each within the scatter of the next); then compound 1.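

In this assay, the steps (a 1.2-fold lower number from compound 3 to compound 4 (0.07 log units; within the scatter)) and (a 1.1-fold higher number from compound 2 to compound 4 (0.03 log units; within the scatter)) show that an amino link on this aromatic carbon between two ring nitrogen atoms is not required for numbers in this range, since acetoxymethyl, with no ring and 0 hydrogen-bond donors, stands level with cyclopropylamino and (4-cyanophenyl)amino. The step (a 5.1-fold lower number from compound 1 to compound 4 (0.70 log units; beyond the scatter)) shows that the earlier split between amino groups and cyclopropylmethoxy does not extend to every non-amino group, so among these four compounds cyclopropylmethoxy alone gives the higher number, and acetoxymethyl goes against any reading of that split as amino against non-amino. Nothing given here accounts for why compound 1 stands apart from the other three.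

The compounds shown leave open whether a plain methyl, a hydroxymethyl or a methoxymethyl group at this position would stay level with compound 4, which would test whether the acetate ester matters or only the carbon link. They also leave open whether a smaller ether such as methoxy would stand with compound 1 or with the other three.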